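The source may hold more compounds than are shown below. What is called first, only, known or untested is meant among the compounds shown, and "the series" means these compounds.

Compound 1 `COc1cc(OC)c(/C=C(/Sc2ccc(C)cc2)C(=O)c2ccc(Cl)cc2)c(OC)c1`: > 100000 nM (a limit)
Compound 2 `COc1cc(OC)c(/C=C(/Sc2ccc(C)cc2)C(=O)c2ccc(Br)cc2)c(OC)c1`: > 100000 nM (a limit)

In a functional assay on DU-145 cells (Homo sapiens) for inhibition, read by trypan blue exclusion, with a stated time of 96 h (a lower number here means a stronger inhibitor of growth, a higher number a weaker inhibitor of growth), compound 1 gives only a limit, > 100000 nM, and not a number. Compound 3 `COc1cc(OC)c(/C=C(\C(=O)c2ccc(Cl)cc2)S(=O)(=O)Cc2ccc(F)cc2)c(OC)c1` keeps the chloro group of compound 1, but (4-fluorobenzyl)sulfonyl takes the place of (4-methylphenyl)sulfanyl: (4-fluorobenzyl)sulfonyl in place of (4-methylphenyl)sulfanyl on a double-bonded chain carbon bound to a carbonyl carbon and a double-bonded chain carbon. Among the measured compounds shown here, the only measured step, a step that the two limits leave unreadable from compound 1 to compound 2, concerns bromo in place of chloro and gives no size to carry over to this change. With compound 1 at the limit of > 100000 nM, a change can only show up as stronger inhibition, so a gain of uncertain size is expected: an at least 20-fold lower number from compound 1 to compound 3 (1.30 log units; beyond the scatter). For compound 3 the estimated value is 5000 nM, with an expected range of 100 nM to 100000 nM.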

Compound 3, concentration for 50% growth inhibition: 25000 nM
For compound 3 the middle estimate is 5.0-fold (0.70 log units) below the measured one; low and high end bracket the measured number.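

In this assay, (4-fluorobenzyl)sulfonyl in place of (4-methylphenyl)sulfanyl gives an at least 4.0-fold lower number from compound 1 to compound 3 (0.60 log units; beyond the scatter), so a change at this place yields a readable number, which the bromo for chloro step, unreadable between two limits, could not. The true size of this gain stays unknown because the step starts from a limit: the limit of > 100000 nM in this assay, at which 2 of the 3 values shown sit.

The change brings in the sulfonyl, the benzyl link and the fluorine together, so the compounds shown do not tell which of them matters. On these data alone, how an amine or a carboxylic acid at this place would behave also remains open.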